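A few compounds are considered here, and "the series" means these few. Any claim that something is new, unique, unknown or untested is made for them only; others in the source may bear on it.

Series notes. Compound 1 `CS(=O)(=O)c1ccc(-c2oc3ccccc3c(=O)c2-c2ccc(F)cc2)cc1` and compound 2 `CS(=O)(=O)c1ccc(-c2oc3ccccc3c(=O)c2-c2cccc(F)c2)cc1` share one core and differ only in the fluorophenyl group two atoms from the ring oxygen. In an assay on isolated protein for inhibition of prostaglandin G/H synthase 1 (Mus musculus), tested at 10 ug/mL (a higher number here means more inhibition at the concentration tested (going by the name of the read-out), a lower number less inhibition), compound 1 gives < 8%, which is a limit of the assay rather than a number. In this assay compound 2 likewise gives < 5%, again a limit and not a number. The step that the two limits leave unreadable from compound 1 to compound 2 therefore cannot be sized; the two limits the limit of < 5% in this assay, at which 1 of the 2 values shown sits, and the limit of < 8% in this assay, at which 1 of the 2 values shown sits, only show that neither compound reaches a readable degree of inhibition. Compound 2 thus stands at the floor of the assay, with no measured neighbour that rises above it.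

Compound 3 `Cc1ccccc1-c1c(-c2ccc(S(C)(=O)=O)cc2)oc2ccccc2c1=O` carries the change (2-methylphenyl in place of 3-fluorophenyl on an aromatic carbon). For the measured compounds named here, the single measured step bears on it only in that both fluorophenyl variants sit at a limit; its size is unreadable, so no direction beyond the scatter can be drawn from it. Compound 3 is expected to remain in the same low region, with the step estimated as a number at least 3 percentage points higher from compound 2 to compound 3 (that floor lies within the scatter). The estimate for compound 3 in this assay is 8%, within 0% to 25%.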

Compound 3, a percentage reported as inhibition, at one concentration (the size of the read-out at that concentration, not a potency): < 5%
Compound 3 was reported as a limit; the forecaster's own chance of this, stated with the estimate: 60%; at least 3 percentage points between middle value and limit.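

No new step can be read among compound 1, compound 2 and compound 3, since all three values are limits of the assay and not numbers, with the most frequent one being: the limit of < 5% in this assay, at which 2 of the 3 values shown sit.

The compounds shown leave open whether any group at this place on the shared core gives readable inhibition in this assay and how far 4-fluorophenyl, 3-fluorophenyl and 2-methylphenyl truly differ.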